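Chloro for Trifluoromethyl: Expecting the Value of Compound 4

This account rests on a few compounds, and the source may have more. Where it says the series, first, only, none or still open, it means among the compounds named here.

Measured compounds:
- Compound 1, `Cc1nc(N[C@@H]2C[C@H]3CC[C@@H]2C3)c2cc(-c3cccc(Cl)c3)ccc2n1`, in a functional assay for positive allosteric modulation of GABA-B receptor (Homo sapiens), read by GTPgammaS binding (a lower number here means that less compound is needed, a higher number that more compound is needed for the effect), compound 1 gives 199 nM
- Compound 2, `Cc1nc(N[C@@H]2C[C@H]3CC[C@@H]2C3)c2cc(-c3cccc(C(F)(F)F)c3)ccc2n1`, compound 2 gives 142 nM
- Compound 3, `FC(F)(F)c1ccc(-c2ccc3nc(Cl)nc(N[C@@H]4C[C@H]5CC[C@@H]4C5)c3c2)cc1`, compound 3 gives 637 nM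

Compound 1 and compound 2 share a core and differ in one place: chloro in place of trifluoromethyl on an aromatic carbon. This change gave a 1.4-fold higher number from compound 2 to compound 1 (0.15 log units; within the scatter), so the two values cannot be told apart. Compound 3 carries a different core; the difference between the two cores is not broken down here, and its value is simply the highest of the three.

Compound 4, `Clc1ccc(-c2ccc3nc(Cl)nc(N[C@@H]4C[C@H]5CC[C@@H]4C5)c3c2)cc1`, is not yet measured. It differs from compound 3 by chloro in place of trifluoromethyl on an aromatic carbon. Among the compounds with values here, this is the same kind of change as the one from compound 2 to compound 1, but not the same: there the chloro sits "meta to a large group", here "para to a large group". Because a 1.4-fold higher number from compound 2 to compound 1 (0.15 log units; within the scatter) stayed within the scatter, the step from compound 3 to compound 4 is expected to be small as well, a 1.2-fold higher number from compound 3 to compound 4 (0.07 log units; within the scatter). Compound 4 is therefore estimated at 750 nM, most likely between 320 nM and 1800 nM.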

Compound 4, half-maximal effective concentration: 208 nM
Compound 4: the middle estimate sits 3.6-fold (0.56 log units) above what was measured; the measured number lies below the stated range.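

In this assay, putting chloro in place of trifluoromethyl on the core of compound 3 gave a 3.1-fold lower number from compound 3 to compound 4 (0.49 log units; beyond the scatter), and the change did not behave alike on the two cores: the same change on two cores in this assay, a 1.4-fold higher number (0.15 log units; within the scatter) from compound 2 to compound 1 and a 3.1-fold lower number (0.49 log units; beyond the scatter) from compound 3 to compound 4, 4.3-fold (0.63 log units) apart, beyond the scatter of two such steps

In this series, then, a step read on one core was not a safe guide to the same swap on the other core. This does not show why the steps differ, since the two pairs differ both in their core and in where the group sits on the ring, para to a large group in compound 3 and compound 4 but not in compound 1 and compound 2, and one pair of each kind cannot separate these two differences.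

The compounds shown leave open whether the larger step follows the core or the position of the group on the ring. They also leave open how a nitrile or a methoxy group in that same place, para to a large group, would compare with chloro and trifluoromethyl.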